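Swapping in 1H-indol-3-yl on the most active compound

This account rests on a few compounds, and the source may have more. Where it says the series, first, only, none or still open, it means among the compounds named here.

Measured in a functional assay on DU-145 cells (Homo sapiens) for inhibition, read by trypan blue exclusion, with a stated time of 96 h; on this read-out higher numbers stand for weaker inhibition of growth and lower numbers for stronger inhibition of growth:
- Compound 1 `Cc1ccc(S/C(=C/c2c[nH]c3ccccc23)C(=O)c2ccc(Br)cc2)cc1`: 10000 nM
- Compound 2 `Cc1ccc(S(=O)(=O)/C(=C/c2ccc(C)s2)C(=O)c2ccc(Br)cc2)cc1`: 25000 nM
- Compound 3 `CSc1ccc(/C=C(\C(=O)c2ccc(Br)cc2)S(=O)(=O)c2ccc(C)cc2)cc1`: 1000 nM

Compound 3 has the lowest of the three numbers, so it inhibits growth most strongly. Compound 4 `Cc1ccc(S(=O)(=O)/C(=C/c2c[nH]c3ccccc23)C(=O)c2ccc(Br)cc2)cc1` differs from it in one group: 1H-indol-3-yl in place of 4-(methylsulfanyl)phenyl on a double-bonded chain carbon bound to a double-bonded chain carbon. For the measured compounds named here, the only measured step at this place is a 25-fold lower number from compound 2 to compound 3 (1.40 log units; beyond the scatter), which shows that this group can move the number a long way. Differing from compound 4 elsewhere in the core, compound 1 also carries 1H-indol-3-yl and gives 10000 nM. Going by the values given here, no measured step isolates this exact swap, so a moderate rise is expected in this assay. The expected change is a 3.0-fold higher number from compound 3 to compound 4 (0.48 log units; beyond the scatter). Compound 4 is estimated at 3000 nM, with an expected range from 600 nM to 15000 nM.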

Compound 4, concentration for 50% growth inhibition: 10000 nM
Beside the measured number, compound 4's estimate is 3.3-fold (0.52 log units) below it, within the range that was stated.
By their numbers in this assay, from the lowest: compound 3; then compounds 1 and 4 (each within the scatter of the next); then compound 2.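

Replacing 4-(methylsulfanyl)phenyl with 1H-indol-3-yl gives a 10-fold higher number from compound 3 to compound 4 (1.00 log units; beyond the scatter) in this assay and replacing 5-methylthiophen-2-yl with it gives a 2.5-fold lower number from compound 2 to compound 4 (0.40 log units; beyond the scatter), which places 1H-indol-3-yl between the other two groups at this place. With 1H-indol-3-yl kept, (4-methylphenyl)sulfonyl in place of (4-methylphenyl)sulfanyl gives no change at the digits printed from compound 1 to compound 4 (within the scatter), so that change shows no effect on growth inhibition in this pair. No available evidence explains this order.

The compounds shown leave open how a group carrying an amine or a carboxylic acid would behave at this place. They also leave open whether the sulfonyl and sulfanyl forms would still match with 4-(methylsulfanyl)phenyl present.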